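The source may report more compounds than this note shows. Statements on the series, on what has been measured and on what is new or still open speak of the compounds shown alone.

Compound 1 `COc1ccc(CNC(=O)COc2ccc3cc(C(O)(C(F)(F)F)C(F)(F)F)c(O)cc3c2)cc1OC`: in an assay on isolated protein for inhibition of tyrosine-protein phosphatase non-receptor type 13 (Homo sapiens), read by spectrophotometry (on this read-out lower numbers stand for stronger inhibition and higher numbers for weaker inhibition), compound 1 gives > 20000 nM, which is a limit of the assay rather than a number.
Compound 2 `O=C(COc1ccc2cc(C(O)(C(F)(F)F)C(F)(F)F)c(O)cc2c1)NCc1ccc(F)cc1`: in this assay compound 2 gives > 20000 nM, again only a limit.

Compound 2 therefore stands at the limit of this assay, with no real number known for it. For the measured compounds named here, the only measured step, a step that the two limits leave unreadable from compound 1 to compound 2, is unreadable because both ends rest at the limit of > 20000 nM in this assay, at which 2 of the 2 values shown sit. Compound 3 `CC(C)c1ccc(NC(=O)COc2ccc3cc(C(O)(C(F)(F)F)C(F)(F)F)c(O)cc3c2)cc1` differs from compound 2 by 4-isopropylphenyl in place of 4-fluorobenzyl on an amide-type nitrogen. Going by the values given here, no measured step gives a readable size for a change of this kind, so nothing beyond the scatter can be foreseen. The step that the limit leaves unreadable from compound 2 to compound 3 is therefore expected to stay in the unreadable region at the limit. Compound 3 is estimated at 30000 nM, within 8000 nM to 150000 nM.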

Compound 3, half-maximal inhibitory concentration: 6500 nM
Compound 3: middle estimate off by 4.6-fold (0.66 log units), on the high side; measured number below the stated range.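

For the compounds shown here, the group on the amide-type nitrogen matters: with 4-isopropylphenyl there, compound 3 gives 6500 nM, the first real number. Replacing 4-fluorobenzyl gives an at least 3.0-fold lower number from compound 2 to compound 3 (0.48 log units; beyond the scatter), and replacing 3,4-dimethoxybenzyl gives an at least 3.0-fold lower number from compound 1 to compound 3 (0.48 log units; beyond the scatter). This position can therefore shift the read-out on the shared core, which the first two compounds could not show.

Each change swaps both the ring substituent and the benzyl group for a phenyl group, so the compounds shown cannot separate these two differences. A 4-isopropylbenzyl group on the same nitrogen would help to tell them apart.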